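A few compounds are considered here, and "the series" means these few. Any claim that something is new, unique, unknown or untested is made for them only; others in the source may bear on it.

Compound 3 `CC(C)CN1CCCC[C@H]1C(=O)Nc1cc(C(C)(C)C)on1` gives 32 ug/mL in a physicochemical assay for solubility, read by HPLC, at pH 6.8 (on this read-out lower numbers stand for lower solubility and higher numbers for higher solubility), the lowest of the two numbers seen, with compound 2 `CC(C)(C)c1cc(NC(=O)[C@@H]2CCCCN2C2CC2)no1` at 38 ug/mL lying within the scatter of it. Compound 1 `CC(C)(C)c1cc(NC(=O)[C@@H]2CCCCN2Cc2ccc(Cl)cc2)no1` gives only a limit, < 0.1 ug/mL, in this assay, which is the limit of < 0.1 ug/mL in this assay, at which 1 of the 3 values shown sits. Compound 4 `CC(C)(C)c1cc(NC(=O)[C@@H]2CCCCN2C2CCOCC2)no1` differs from compound 3 by oxan-4-yl in place of isobutyl on an amine nitrogen in a ring. Of the measured steps, a 1.2-fold lower number from compound 2 to compound 3 (0.07 log units; within the scatter) bears most closely, as it also swaps one small substituent for another on the same nitrogen; the large steps of an at least 380-fold higher number from compound 1 to compound 2 (2.57 log units; beyond the scatter) and an at least 320-fold higher number from compound 1 to compound 3 (2.50 log units; beyond the scatter) concern the 4-chlorobenzyl instead. Compound 4 is therefore expected to show a 1.6-fold higher number from compound 3 to compound 4 (0.19 log units; within the scatter), no change beyond the scatter or a modest rise. Compound 4 is estimated at 50 ug/mL, between 18 ug/mL and 150 ug/mL.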

Compound 4, solubility: 74 ug/mL
Compound 4: the middle estimate sits 1.5-fold (0.17 log units) below what was measured; measured number inside the range.
By their numbers in this assay, from the lowest: compounds 3, 2 and 4 (each within the scatter of the next, the first and the last beyond it). At a limit, below all of these: compound 1.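

In this assay, among the compounds shown here, oxan-4-yl on this amine nitrogen gives the first step among the small substituents to pass the scatter, a 2.3-fold higher number from compound 3 to compound 4 (0.36 log units; beyond the scatter), although a 1.9-fold higher number from compound 2 to compound 4 (0.29 log units; within the scatter) stays within it. The value of compound 1 is a limit and not a number, so an at least 740-fold higher number from compound 1 to compound 4 (2.86 log units; beyond the scatter) gives only a bound: the limit of < 0.1 ug/mL in this assay, at which 1 of the 4 values shown sits.

The compounds shown leave open whether the higher number goes with the oxygen of oxan-4-yl or with its ring alone, and cyclohexyl on the same nitrogen would separate the two. On these data alone, how a group carrying an amine or a carboxylic acid would read there also stays open.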